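The source may report more compounds than this note shows. Statements on the series, on what has been measured and on what is new or still open speak of the compounds shown alone.

Measured compounds:
Compound 1 `COc1cc(/C=C/c2ccc(NC(=O)/C=C/c3cc(OC)c(OC)c(OC)c3)cc2)cc(OC)c1` gives 2140 nM in a functional assay on MDA-MB-231 cells (Homo sapiens) for inhibition, read by MTT assay, with a stated time of 48 h; on this read-out lower numbers stand for stronger inhibition and higher numbers for weaker inhibition.
Compound 2 `COc1cc(/C=C/c2ccc(NC(=O)/C=C/c3ccc(C(F)(F)F)cc3)cc2)cc(OC)c1` gives 3520 nM in this assay.

Among the measured compounds shown here, compound 2 stands at one end of these two numbers, yet the gap to compound 1, its only neighbour, lies within the usual scatter of repeated measurements, so the two compounds cannot be told apart on this read-out. For the measured compounds named here, no step between measured compounds that differ in a single place is available in this set.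

Compound 3 `COc1cc(/C=C/c2ccc(NC(=O)/C=C/c3ccccc3F)cc2)cc(OC)c1` has not yet been measured in this assay. It differs from compound 2 in one place: 2-fluorophenyl in place of 4-(trifluoromethyl)phenyl on a double-bonded chain carbon bound to a double-bonded chain carbon. Going by the values given here, nothing among the measured pairs shows how such a change moves the numbers, so no direction can be read from the data; the expectation for compound 3 is a step of a 1.1-fold lower number from compound 2 to compound 3 (0.04 log units; within the scatter) that does not go beyond the scatter. Compound 3 is therefore estimated at 3200 nM, with a likely range from 1200 nM to 8500 nM.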

Compound 3, half-maximal inhibitory concentration: 2380 nM
For compound 3 the middle estimate is 1.3-fold (0.13 log units) above the measured one, and the stated range covers the measured number.
By their numbers in this assay, from the lowest: compounds 1, 3 and 2 (each within the scatter of the next).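

Among the compounds shown here, this is the first comparison in the set between compounds that differ in one place: in this assay, 2-fluorophenyl in place of 4-(trifluoromethyl)phenyl on a double-bonded chain carbon bound to a double-bonded chain carbon gives a 1.5-fold lower number from compound 2 to compound 3 (0.17 log units; within the scatter). This read-out therefore does not tell these two groups apart at this position, although the exchange alters both the fluorine-bearing group and the group's size as counted in heavy atoms. No independent evidence bears on this result.

For the compounds shown here, the single pair cannot separate the loss of the trifluoromethyl group from the arrival of the fluorine atom, nor show whether either matters at this position. It also leaves open whether a group of another kind here, such as an amine or a carboxylic acid, would give a number beyond the scatter.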